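From 3-chlorophenyl to 4-chlorophenyl: compound 2 to compound 3

The source may hold more compounds than are shown below. What is called first, only, known or untested is meant among the compounds shown, and "the series" means these compounds.

- compound 1 `O=C1Nc2ccccc2/C1=C/c1ccc(-c2cn(-c3cccc(F)c3)nn2)cc1` gives > 20000 nM as a limit
- compound 2 `O=C1Nc2ccccc2/C1=C/c1ccc(-c2cn(-c3cccc(Cl)c3)nn2)cc1` gives > 20000 nM as a limit

In an ADME assay on HUVEC cells (Homo sapiens) for inhibition, read by CCK-8 assay, with a stated time of 24 h, in the presence of a further agent that is not named here (a higher number here means a weaker inhibitor, a lower number a stronger inhibitor), compound 2 stands at > 20000 nM, which is a limit and not a number. For the measured compounds named here, the series so far offers only the limit of > 20000 nM in this assay, at which 2 of the 2 values shown sit, as its evidence. Compound 3 `O=C1Nc2ccccc2/C1=C/c1ccc(-c2cn(-c3ccc(Cl)cc3)nn2)cc1` has 4-chlorophenyl in place of 3-chlorophenyl on an aromatic nitrogen of a five-membered aromatic ring with 3 nitrogen. Going by the values given here, the one measured step that bears on this change is a step that the two limits leave unreadable from compound 1 to compound 2, so no size carries over from it. No step beyond the scatter is expected in this assay, in either direction, and another limit is the likely report. The expected step is a step that the limit leaves unreadable from compound 2 to compound 3 as an estimate. For compound 3 the estimated value is 25000 nM, with an expected range from 10000 nM to 60000 nM.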

Compound 3, half-maximal inhibitory concentration: 18200 nM
For compound 3 the middle estimate is 1.4-fold (0.14 log units) above the measured one; measured number inside the range.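

In this assay compound 3 gives 18200 nM, so 4-chlorophenyl on the aromatic nitrogen yields a measured number. Compound 1 and compound 2 gave only limits. The change from 3-chlorophenyl reads as an at least 1.0-fold lower number from compound 2 to compound 3 (0.04 log units; that floor lies within the scatter), and the change from 3-fluorophenyl reads as an at least 1.0-fold lower number from compound 1 to compound 3 (0.04 log units; that floor lies within the scatter), so neither step establishes a real difference at this position. Both floors rest on limits, which leaves the true size of each step undetermined: the limit of > 20000 nM in this assay, at which 2 of the 3 values shown sit.

As far as these compounds go, the step from compound 1 to compound 2 cannot be read, so the effect of chloro in place of fluoro stays open. Also open, from the compounds shown here alone, is whether an amine, a carboxylic acid or a methoxy group on this phenyl ring would give a step beyond the scatter.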